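The compounds below may be only part of what the source reports. "The series", "measured", "known", "first", "only" and "open" are said of these compounds alone.

Measured in a functional assay on KB cells (Homo sapiens) for cytotoxicity, with a stated time of 3 days; on this read-out higher numbers stand for weaker inhibition and lower numbers for stronger inhibition:

Compound 1 `O=c1cc(-c2ccccc2)oc2cc(O)c(OCc3ccccc3)c(O)c12`: 4300 nM
Compound 2 `CCCOc1c(O)cc2oc(-c3ccccc3)cc(=O)c2c1O`: 58900 nM

Among the compounds with values here, of these two numbers, compound 2 has the higher, 58900 nM, so it is the weaker inhibitor of the pair, and compound 1 is its only neighbour. Compound 3 `CC(=O)Oc1c(O)cc2oc(-c3ccccc3)cc(=O)c2c1O` has not yet been measured. It shares the core of compound 2 and differs from it in one place: acetyl in place of propyl on an oxygen on an aromatic ring.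

Within the data shown here, only one measured step bears on this change: a 14-fold higher number from compound 1 to compound 2 (1.14 log units; beyond the scatter). That large step, beyond the scatter, replaced phenyl with ethyl on a saturated chain carbon bound to an oxygen on an aromatic ring. It involved the loss of a ring, whereas the change to compound 3 neither adds nor removes one. It therefore offers no basis for expecting a large step in this assay, and no data show the effect of acetyl itself. The expected change is small, toward a lower number and not clearly beyond the scatter: a 1.7-fold lower number from compound 2 to compound 3 (0.23 log units; within the scatter). For compound 3 the estimated value is 35000 nM, with an expected range from 9000 nM to 100000 nM.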

Compound 3, half-maximal inhibitory concentration: 10500 nM
Beside the measured number, compound 3's estimate is 3.3-fold (0.52 log units) above it; the measured number falls inside the stated range.
By their numbers in this assay, from the lowest: compound 1; then compound 3; then compound 2.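

In this assay the group on this oxygen moves the number even when no ring is gained or lost, something the earlier pair could not show, since its two compounds differed by a ring. Acetyl in place of propyl gave a 5.6-fold lower number from compound 2 to compound 3 (0.75 log units; beyond the scatter) and thus a change beyond the scatter between two small groups of equal heavy-atom count, while acetyl in place of benzyl gave a 2.4-fold higher number from compound 1 to compound 3 (0.39 log units; beyond the scatter) and so left the benzyl compound, compound 1, with the lowest number of the three. Nothing at hand explains why these groups rank in this order.

The compounds shown leave open whether the lower number of compound 3 relative to compound 2 goes with the carbonyl of the acetyl group or with some other difference between propoxy and acetoxy, and a longer acyl chain such as butanoyl on the same oxygen would bear on that. They also leave open whether benzoyl, which carries both a ring and a carbonyl, would give a number lower than that of compound 1.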